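From Fluoro to Sulfamoyl in an Antiproliferative Series

This account rests on a few compounds, and the source may have more. Where it says the series, first, only, none or still open, it means among the compounds named here.

Among the compounds with values here, in a functional assay on HeLa cells (Homo sapiens) for antiproliferative activity, read by sulforhodamine B assay, with a stated time of 72 h (on this read-out higher numbers stand for weaker inhibition and lower numbers for stronger inhibition), compound 2 (`Fc1ccc(Nc2nncc3ccccc23)cc1`) gives 2.8 nM and holds the lower of the two numbers so far. Compound 1 (`COc1ccc(NC(=S)NNc2nncc3ccccc23)cc1`) gives 38 nM in the same read-out, a gap beyond the scatter, although these two compounds differ in more than one place and the gap cannot be assigned to any single change.

The next compound to be read is compound 3 (`NS(=O)(=O)c1ccc(Nc2nncc3ccccc23)cc1`). It keeps the shared core of compound 2 and carries sulfamoyl in place of fluoro on an aromatic carbon, para to a large group (sulfamoyl in place of fluoro on an aromatic carbon). Within the data shown here, no measured pair shows a change at this place, so the data offer no direct guide to its size.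

In this assay, among the measured compounds shown here, a step toward a higher number, beyond the scatter, is expected because compound 2 stands at 2.8 nM as the lowest number so far. The estimated change is an 8.9-fold higher number from compound 2 to compound 3 (0.95 log units; beyond the scatter) with wide uncertainty. Compound 3 is expected at 25 nM with an estimated range from 4 nM to 150 nM for now.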

Compound 3, half-maximal inhibitory concentration: 12 nM
Compound 3: the middle estimate sits 2.1-fold (0.32 log units) above what was measured; the measured number falls inside the stated range.
By their numbers in this assay, from the lowest: compound 2; then compound 3; then compound 1.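

In this assay the aromatic carbon para to a large group now has its first measured change: sulfamoyl in place of fluoro gives a 4.3-fold higher number from compound 2 to compound 3 (0.63 log units; beyond the scatter) on the shared core. Within the data shown here, this shows that the read-out responds to this position beyond the usual scatter, which the earlier compounds could not show, and that a group of 4 heavy atoms with a hydrogen-bond donor and acceptors can replace a single fluorine while compound 3 still reads 12 nM in the same assay. No supporting measurement bears on the step, so the feature of the exchange behind it stays unassigned. 

This single pair leaves open whether the step follows the loss of fluoro, the entry of sulfamoyl, or both, and a plain hydrogen at this place would help separate those readings. Also open, as far as these compounds go, is how an amine, a carboxylic acid, a methyl sulfone or an N-methyl sulfonamide at the same carbon would read in this assay relative to compound 2 and compound 3, and whether the size of this step holds on any other core.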